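The source may report more compounds than this note shows. Statements on the series, on what has been measured and on what is new or still open speak of the compounds shown alone.

Measured so far in a functional assay on the whole organism (Tail, strain ICR) with Mus musculus as the target, in the tail flick test, with a stated time of 90 min, at a dose of 25 umol/kg by the oral route; on this read-out lower numbers stand for a weaker effect and higher numbers for a stronger effect at the one dose given:
Compound 1 `O=C(CN(c1nc(Cl)nc2[nH]cnc12)C1CC1)NCC(=O)OCc1ccccc1` gives 27.2%.
Compound 2 `N=C(N)NCCC[C@H](NC(=O)CN(c1nc(Cl)nc2[nH]cnc12)C1CC1)C(=O)O` gives 27.6%.
Compound 3 `CC[C@H](C)[C@H](NC(=O)CN(c1ncnc2c1ncn2C1CCCCO1)C1CC1)C(=O)OCc1ccccc1` gives 22.6%.

Compound 3 has the lowest of the three numbers in this assay, but the gaps to compound 1 and compound 2 are within the scatter, so no ranking among the three can be read. Compound 4 `CC(C)C[C@H](NC(=O)CN(c1ncnc2c1ncn2C1CCCCO1)C1CC1)C(=O)OCc1ccccc1` is next to be measured. It differs from compound 3 in one place, (isobutyl in place of sec-butyl on a saturated chain carbon bound to an amide-type nitrogen and a carbonyl carbon), the two having the same atoms joined differently. Among the measured compounds shown here, no step between measured compounds bears on this change, and the measured values themselves span less than the scatter. For compound 4 the step of a number 1.4 percentage points higher from compound 3 to compound 4 (within the scatter) is expected, that is none beyond the scatter. Compound 4 is therefore estimated at 24%, with a range from 12% to 37%.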

Compound 4, a percentage reported as activity, at one dose (the size of the read-out at that dose, not a potency): 28.2%
Compound 4: middle estimate off by 4.2 percentage points, on the low side; the measured number falls inside the stated range.
By their numbers in this assay, from the lowest: compounds 3, 1, 2 and 4 (each within the scatter of the next).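

In this assay, the first step read at this position is a number 5.6 percentage points higher from compound 3 to compound 4 (within the scatter) for isobutyl in place of sec-butyl on a saturated chain carbon bound to an amide-type nitrogen and a carbonyl carbon. This rearrangement of the same atoms, which also removes the defined stereocentre of sec-butyl, gives no difference that can be read at this dose. No measurement bears on the reason for this result. Still open, from the compounds shown here alone, is whether an n-hexyl chain or a primary amine at this place would give a step beyond the scatter.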